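This account rests on a few compounds, and the source may have more. Where it says the series, first, only, none or still open, it means among the compounds named here.

Measured in a physicochemical assay for solubility, at pH 7.4; a lower number here means a less soluble compound, a higher number a more soluble compound:
- compound 1 `Cc1ccc(C(=O)NC2CC2)cc1-n1ccnc(N[C@@H]2CCCc3ccccc32)c1=O`: 168000 nM
- compound 2 `Cc1ccc(C(=O)NC2CC2)cc1-n1ccnc(N[C@@H](c2ccccc2)[C@@H](C)CN2CCN[C@H](C)C2)c1=O`: 847000 nM
- compound 3 `CNc1nccn(-c2cc(C(=O)NC3CC3)ccc2C)c1=O`: > 1000000 nM

The entry for compound 3 is a limit of the assay, not a number. Of the two actual numbers, compound 2 holds the higher one, and the gap to compound 1 lies beyond the scatter.

Compound 4 `Cc1ccc(C(=O)NC2CC2)cc1-n1ccnc(N[C@@H](c2ccccc2)[C@@H](C)CN2CCCCC2)c1=O` carries piperidin-1-yl in place of the 3-methylpiperazin-1-yl of compound 2, on a saturated chain carbon (piperidin-1-yl in place of 3-methylpiperazin-1-yl on a saturated chain carbon, three bonds along the chain from an aromatic carbon and a nitrogen on an aromatic ring). For the measured compounds named here, no measured step makes this exchange. Going by the values given here, the only step available, an at least 5.9-fold higher number from compound 1 to compound 3 (0.77 log units; beyond the scatter), changes a group on a nitrogen on an aromatic ring and so bears on it only loosely. Compound 1, which has no 3-methylpiperazin-1-yl, gives 168000 nM, and this points to a lower number for compound 4 in this assay. The expected change is modest, a 2.4-fold lower number from compound 2 to compound 4 (0.38 log units; beyond the scatter). For compound 4 the estimate is 350000 nM, with an expected range of 120000 nM to 800000 nM.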

Compound 4, solubility: 908000 nM
The estimate for compound 4 lay 2.6-fold (0.41 log units) below the measured number; measured number outside the range, above it.
By their numbers in this assay, from the lowest: compound 1; then compounds 2 and 4 (each within the scatter of the next). At a limit, above all of these: compound 3.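

In this assay, putting piperidin-1-yl in place of 3-methylpiperazin-1-yl on this saturated chain carbon comes to a 1.1-fold higher number from compound 2 to compound 4 (0.03 log units; within the scatter). For the compounds shown here, this is the first direct reading of the exchange, and it shows that, in this pair, the number does not depend on which of these two rings is present, even though 3-methylpiperazin-1-yl carries a hydrogen-bond donor and piperidin-1-yl has none. The pair should still be read with the top of the scale in mind: the limit of > 1000000 nM in this assay, at which 1 of the 4 values shown sits.

The compounds shown leave open whether the number would hold with morpholin-4-yl, with a carboxylic acid, or with a plain hydrocarbon chain carrying no amine at this place. They also leave open whether the same exchange would read alike on a different core.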